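Series notes: amine substituent variation on the pyridinone side chain

The compounds below may be only part of what the source reports. "The series", "measured", "known", "first", "only" and "open" are said of these compounds alone.

Measured so far:
compound 1 `CCCCc1ccc(CNC(=O)OC(C)(C)C)c(=O)n1Cc1ccc(-c2ccccc2-c2nn[nH]n2)cc1` — 10 nM
compound 2 `CCCCc1ccc(CNCc2ccccc2)c(=O)n1Cc1ccc(-c2ccccc2-c2nn[nH]n2)cc1` — 1 nM
compound 3 `CCCCc1ccc(CN(C)S(=O)(=O)c2ccccc2)c(=O)n1Cc1ccc(-c2ccccc2-c2nn[nH]n2)cc1` — 2 nM

All three share one core and differ only in the group carried on the saturated chain carbon bound to an aromatic carbon. In a functional assay (aorta) for antagonist activity, with Oryctolagus cuniculus as the target (a higher number here means a weaker inhibitor, a lower number a stronger inhibitor), compound 1 gives 10 nM, compound 2 gives 1 nM and compound 3 gives 2 nM. The step of a 10-fold lower number from compound 1 to compound 2 (1.00 log units; beyond the scatter) and the step of a 5.0-fold lower number from compound 1 to compound 3 (0.70 log units; beyond the scatter) both run in the same direction and are beyond the scatter, while the step of a 2.0-fold higher number from compound 2 to compound 3 (0.30 log units; within the scatter) is within the scatter, so compound 3 stands second of the three numbers with its nearest neighbour compound 2 indistinguishable from it and compound 1 clearly weaker.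

The next compound, compound 4 `CCCCc1ccc(CN(CC)S(C)(=O)=O)c(=O)n1Cc1ccc(-c2ccccc2-c2nn[nH]n2)cc1`, carries the change (ethyl(methylsulfonyl)amino in place of methyl(phenylsulfonyl)amino on a saturated chain carbon bound to an aromatic carbon). Going by the values given here, no measured step removes the aromatic ring from this substituent; the steps from compound 1 bear only on swapping the tert-butoxycarbonyl for groups that keep such a ring, and the step from compound 2 to compound 3 shows that exchanging benzylamino for methyl(phenylsulfonyl)amino made no difference beyond the scatter. With the ring gone, a modest rise in this assay is expected, though none beyond the scatter would not be surprising. For compound 4 the estimate is 5 nM, with a range of 1.5 nM to 20 nM, which is expected to read as the step of a 2.5-fold higher number from compound 3 to compound 4 (0.40 log units; beyond the scatter).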

Compound 4, half-maximal inhibitory concentration: 2 nM
For compound 4 the middle estimate is 2.5-fold (0.40 log units) above the measured one; low and high end bracket the measured number.
By their numbers in this assay, from the lowest: compounds 2, 3 and 4 (each within the scatter of the next); then compound 1.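

In this assay, replacing methyl(phenylsulfonyl)amino with ethyl(methylsulfonyl)amino, which has no ring and fewer heavy atoms, on a saturated chain carbon bound to an aromatic carbon gives (no change at the digits printed from compound 3 to compound 4 (within the scatter)), so an aromatic ring in this substituent is not needed to hold the number. The comparison with benzylamino reads the same (a 2.0-fold higher number from compound 2 to compound 4 (0.30 log units; within the scatter)), and the step away from (tert-butoxycarbonyl)amino survives without any ring in the entering group (a 5.0-fold lower number from compound 1 to compound 4 (0.70 log units; beyond the scatter)), so across compounds 2, 3 and 4 the lower number does not depend on such a ring. No measurement at hand explains these results.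

Open, on these data alone, is how a primary amine or a carboxylic acid in this place would read. Also open, as far as these compounds go, is whether a chain longer than ethyl on the nitrogen of ethyl(methylsulfonyl)amino would keep the number.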